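A few compounds are considered here, and "the series" means these few. Any claim that something is new, unique, unknown or untested is made for them only; others in the source may bear on it.

Series notes, agonist read-out. Compound 1 `CC(C)(C)OC(=O)N1CCC(Oc2cccc3c2CCN3c2ccc(S(C)(=O)=O)cc2)CC1` gives 158 nM in a functional assay on CHO-K1 cells for agonist activity at Glucose-dependent insulinotropic receptor (Homo sapiens), read by a luciferase reporter, with a stated time of 5 h; on this read-out higher numbers stand for an effect only at larger amounts of compound and lower numbers for an effect already at smaller amounts. Compound 2 `CC(C)OC(=O)N1CCC(Oc2cccc3c2CCN3c2ccc(S(C)(=O)=O)cc2F)CC1` gives 1000 nM in this assay. For the measured compounds named here, compound 3 `CC(C)COC(=O)N1CCC(Oc2ncnc3c2CCN3c2ccc(S(C)(=O)=O)cc2F)CC1` gives 25.1 nM in this assay, the lowest of the three numbers so far; compound 1 sits at a higher number beyond the scatter, and compound 2 higher still, also beyond the scatter. These three compounds differ from one another in more than one place, so their values are reported without further comparison.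

Compound 4 `CC(C)c1noc(N2CCC(Oc3ncnc4c3CCN4c3ccc(S(C)(=O)=O)cc3F)CC2)n1` has not been measured. It differs from compound 3 by 3-isopropyl-1,2,4-oxadiazol-5-yl in place of isobutoxycarbonyl on an amine nitrogen in a ring. Going by the values given here, the carbamate is replaced by a five-membered aromatic ring; no measured pair shows this change, so the expected step is set at none beyond the scatter. In this assay compound 4 is expected at 30 nM, within 8 nM to 120 nM. The expected step of a 1.2-fold higher number from compound 3 to compound 4 (0.08 log units; within the scatter) is estimated, not measured.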

Compound 4, half-maximal effective concentration: 79.4 nM
For compound 4 the middle estimate is 2.6-fold (0.42 log units) below the measured one; the range from low to high includes it.
By their numbers in this assay, from the lowest: compound 3; then compounds 4 and 1 (each within the scatter of the next); then compound 2.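

For the compounds shown here, on the amine nitrogen in the ring, 3-isopropyl-1,2,4-oxadiazol-5-yl in place of isobutoxycarbonyl gives a 3.2-fold higher number from compound 3 to compound 4 (0.50 log units; beyond the scatter) in this assay, the first single-place comparison. The carbamate is therefore not required for agonist activity at this position, although the isobutoxycarbonyl compound keeps the lower number. Nothing measured here bears on the reason for this step.

Open, on these data alone, is whether a urea or a pyrimidine ring on the same nitrogen would match isobutoxycarbonyl. Also open, as far as these compounds go, is whether a cyclopropyl or tert-butyl group in place of the isopropyl on the oxadiazole would shift the number.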